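From anilino to amino: removing the phenyl of compound 1

The source may report more compounds than this note shows. Statements on the series, on what has been measured and on what is new or still open speak of the compounds shown alone.

Measured so far:
- compound 1 `S=C(NNc1nncc2ccccc12)Nc1ccccc1`: 6 nM
- compound 2 `COc1ccc(NC(=S)NNc2nncc3ccccc23)cc1`: 73 nM
- compound 3 `O=C1CS/C(=N/Nc2nncc3ccccc23)N1`: 46 nM

In a functional assay on OVCAR-3 cells (Homo sapiens) for antiproliferative activity, read by sulforhodamine B assay, with a stated time of 72 h (a higher number here means a weaker inhibitor, a lower number a stronger inhibitor), compound 1 gives 6 nM, the lowest of the three numbers and clearly below the other two. Compound 4 `NC(=S)NNc1nncc2ccccc12` has not yet been measured. It departs from compound 1 as follows: hydrogen in place of phenyl on an amide-type nitrogen. In words, hydrogen stands in place of phenyl on an amide-type nitrogen, so anilino becomes amino.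

Among the compounds with values here, only one measured step bears on this change, since it is the only one that alters the phenyl of compound 1. That step, a 12-fold higher number from compound 1 to compound 2 (1.09 log units; beyond the scatter), is large and beyond the scatter, and it comes from methoxy in place of hydrogen on an aromatic carbon. Compound 4 loses the whole phenyl, so a change of similar size is expected in this assay, towards a higher number, though one step is thin support. The expected step is a 10-fold higher number from compound 1 to compound 4 (1.00 log units; beyond the scatter). For compound 4 the estimated value is 60 nM, with an expected range of 15 nM to 250 nM.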

Compound 4, half-maximal inhibitory concentration: 74 nM
Beside the measured number, compound 4's estimate is 1.2-fold (0.09 log units) below it, within the range that was stated.
By their numbers in this assay, from the lowest: compound 1; then compounds 3, 2 and 4 (each within the scatter of the next).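

In this assay the change from anilino to amino gives a 12-fold higher number from compound 1 to compound 4 (1.09 log units; beyond the scatter), so on this amide-type nitrogen the low number of compound 1 does not survive with hydrogen in place of phenyl. The earlier compounds shown here showed only a change on that phenyl, methoxy in place of hydrogen, which gives a 12-fold higher number from compound 1 to compound 2 (1.09 log units; beyond the scatter); the two steps are printed at the same size, so here adding methoxy to the phenyl and removing the phenyl altogether both raise the number by as much. No measurement at hand explains this response at the position.

On these data alone, it remains open whether a methyl or a benzyl on this nitrogen would keep the low number of compound 1. As far as these compounds go, whether a chlorine or a hydroxyl on the phenyl would act as methoxy does also remains open.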